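A few compounds are considered here, and "the series" means these few. Any claim that something is new, unique, unknown or untested is made for them only; others in the source may bear on it.

Measured compounds in a functional assay on CHO-K1 cells for antagonist activity at C-X-C chemokine receptor type 3 (Homo sapiens), read by FLIPR, with a stated time of 10 min, in the presence of a further agent that is not named here; on this read-out higher numbers stand for weaker inhibition and lower numbers for stronger inhibition:
compound 1 `Cc1nc(C)n(CC(=O)N2CCN(c3sc(C(F)(F)F)nc3-c3nc4c(F)cccc4[nH]3)C[C@H]2C)n1` gives 3.1 nM
compound 2 `C[C@@H]1CN(c2sc(C(F)(F)F)nc2-c2nc3cc(Cl)ccc3[nH]2)CCN1C(=O)Cn1cnc2cccnc21` gives 2.8 nM
compound 3 `Cc1nc(C)n(CC(=O)N2CCN(c3sc(C(F)(F)F)nc3-c3nc4c(C(F)(F)F)cccc4[nH]3)C[C@H]2C)n1` gives 6 nM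

Compound 1 stands second highest of the three numbers; its nearest neighbour is compound 2, whose number sits within the scatter of it, and its furthest is compound 3, also within the scatter. Among the measured compounds shown here, the one single-point step among the measured compounds is a 1.9-fold higher number from compound 1 to compound 3 (0.29 log units; within the scatter), which is within the scatter.

Compound 4 `Cc1nc(C)n(CC(=O)N2CCN(c3sc(C(F)(F)F)nc3-c3nc4cccc(C)c4[nH]3)C[C@H]2C)n1` differs from compound 1 by 7-methyl-1H-benzimidazol-2-yl in place of 4-fluoro-1H-benzimidazol-2-yl on an aromatic carbon. For the measured compounds named here, no measured step covers a methyl at this position of the benzimidazole. Going by the values given here, the only step that bears on a change at this part of the shared core is a 1.9-fold higher number from compound 1 to compound 3 (0.29 log units; within the scatter), and it stayed within the scatter; compound 2 carries a different substitution pattern on its benzimidazole and also sits within the scatter of compound 1. On that basis no change beyond the scatter is expected in this assay for compound 4, in either direction.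

Compound 4 is therefore estimated at 4 nM in this assay, with a range of 1.5 nM to 12 nM, which means an expected step of a 1.3-fold higher number from compound 1 to compound 4 (0.11 log units; within the scatter).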

Compound 4, half-maximal inhibitory concentration: 3.1 nM
Compound 4: middle estimate off by 1.3-fold (0.11 log units), on the high side; measured number inside the range.
By their numbers in this assay, from the lowest: compounds 2, 1, 4 and 3 (each within the scatter of the next, the first and the last beyond it).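

In this assay, 7-methyl-1H-benzimidazol-2-yl in place of 4-fluoro-1H-benzimidazol-2-yl gives no change at the digits printed from compound 1 to compound 4 (within the scatter), so a methyl can stand on the benzimidazole in place of the fluoro with no readable change. Read with a 1.9-fold higher number from compound 1 to compound 3 (0.29 log units; within the scatter), neither the methyl nor the trifluoromethyl replacement of the fluoro moves the number beyond the scatter, and no group shown here separates from fluoro on this read-out. No measured evidence accounts for this flat response.

On these data alone, whether an amine, a carboxylic acid or a longer chain such as propyl on the benzimidazole would also stay within the scatter remains open. With every step from compound 1 at this part of the shared core within the scatter, the compounds shown do not mark any limit on what this part accepts.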